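Swapping methyl for fluoro on the outer ring

The compounds below may be only part of what the source reports. "The series", "measured", "known", "first", "only" and "open" are said of these compounds alone.

For the measured compounds named here, the three compounds measured so far share one core and differ only in the aromatic ring attached through an amide-type nitrogen. Compound 1 `CN(C)C(=O)c1cc2cnc(Nc3ccc(NC(=O)C4(C(=O)Nc5ccccc5F)CC4)cc3)nc2n1C1CCCC1` carries a 2-fluorophenyl there and in a functional assay on A549 cells (Homo sapiens) for inhibition, read by CCK-8 assay, with a stated time of 72 h, tested at 1 uM (a lower number here means less inhibition of growth, a higher number more inhibition of growth at the concentration tested), compound 1 gives 79.1%. Compound 2 `Cc1ccc(NC(=O)C2(C(=O)Nc3ccc(Nc4ncc5cc(C(=O)N(C)C)n(C6CCCC6)c5n4)cc3)CC2)cc1` carries a 4-methylphenyl and gives 40.2%, the lowest of the three numbers. Compound 3 `COC(=O)c1ccc(NC(=O)C2(C(=O)Nc3ccc(Nc4ncc5cc(C(=O)N(C)C)n(C6CCCC6)c5n4)cc3)CC2)cc1` carries a 4-(methoxycarbonyl)phenyl and gives 77.1%.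

Compound 4 `CN(C)C(=O)c1cc2cnc(Nc3ccc(NC(=O)C4(C(=O)Nc5ccc(F)cc5)CC4)cc3)nc2n1C1CCCC1` is the unmeasured compound. It differs from compound 2 in one place: fluoro in place of methyl on an aromatic carbon.

Going by the values given here, two measured steps bear on this change. The step of a number 38.9 percentage points lower from compound 1 to compound 2 (beyond the scatter) shows how much was lost when the 2-fluorophenyl of compound 1 became the 4-methylphenyl of compound 2. The step of a number 36.9 percentage points higher from compound 2 to compound 3 (beyond the scatter) shows how much was regained when the methyl on that ring was replaced by methoxycarbonyl. In both cases the ring with methyl stands far below the other two. Among the compounds with values here, no measured step tells directly what fluoro on this aromatic carbon does, so the expectation rests on the methyl-bearing ring being the weak outlier.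

Compound 4 is therefore expected to sit at 65%, within 42% to 85%, an estimated step of a number 24.8 percentage points higher from compound 2 to compound 4 (beyond the scatter) upward, though the chance remains that it stays close to compound 2.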

Compound 4, percent growth inhibition at one concentration: 86.6%
Compound 4: middle estimate off by 21.6 percentage points, on the low side, and the stated range ends below it.
By their numbers in this assay, from the lowest: compound 2; then compounds 3, 1 and 4 (each within the scatter of the next).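

Read directly in this assay, fluoro in place of methyl on this aromatic carbon gives a number 46.4 percentage points higher from compound 2 to compound 4 (beyond the scatter) and so recovers the whole gap that separated the methyl-bearing ring from the other two rings. The other two comparisons, a number 9.5 percentage points higher from compound 3 to compound 4 (within the scatter) and a number 7.5 percentage points higher from compound 1 to compound 4 (within the scatter), show that the 4-fluorophenyl cannot be told apart from the 4-(methoxycarbonyl)phenyl and that the 2-fluorophenyl and 4-fluorophenyl rings also cannot be separated in this assay at this single concentration. Among these four compounds, only compound 2 stands apart, with all three of its steps beyond the scatter, so the low number belongs to the 4-methylphenyl ring alone rather than to a general sensitivity to what sits on that ring.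

Nothing available here accounts for the gap between methyl and the other groups on this ring. From the compounds shown here alone, it also remains open whether the low number is specific to methyl or would be shared by an ethyl, a methoxy or an amine on the same aromatic carbon.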